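Methyl on the Phenyl Ring of Compound 2

The source may report more compounds than this note shows. Statements on the series, on what has been measured and on what is new or still open speak of the compounds shown alone.

Compound 1 `Cc1c(CC(C)C)c(=O)on1C(=O)N1CCC(c2ccccc2)CC1` gives 10 nM in an assay (strain Wistar) for inhibition of Hormone-sensitive lipase (Rattus norvegicus), read by spectrophotometry; a lower number here means a stronger inhibitor, a higher number a weaker inhibitor.
Compound 2 `COCCc1c(C)n(C(=O)N2CCC(c3ccccc3)CC2)oc1=O` gives 11 nM in this assay.

Compound 2 holds the highest of the two numbers measured in this assay, its nearest neighbour being compound 1, and the step of a 1.1-fold higher number from compound 1 to compound 2 (0.04 log units; within the scatter) lies within the scatter. Compound 3 `COCCc1c(C)n(C(=O)N2CCC(c3cccc(C)c3)CC2)oc1=O` differs from compound 2 by methyl in place of hydrogen on an aromatic carbon, which, cut one bond further out, reads phenyl to 3-methylphenyl. Among the measured compounds shown here, no measured step touches that ring: the one step on record, a 1.1-fold higher number from compound 1 to compound 2 (0.04 log units; within the scatter), concerns the side chain on the shared core and was within the scatter. For the measured compounds named here, there is thus no step that bears directly on the change from compound 2 to compound 3, and the expectation rests on the narrow spread of the two measured numbers. On that basis the step of no change at the digits printed from compound 2 to compound 3 (within the scatter) is expected to stay within the scatter, with no direction favoured. Compound 3 is estimated at 11 nM, in the range 4 nM to 30 nM.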

Compound 3, half-maximal inhibitory concentration: 23 nM
The estimate for compound 3 lay 2.1-fold (0.32 log units) below the measured number, within the range that was stated.
By their numbers in this assay, from the lowest: compounds 1 and 2 (each within the scatter of the next); then compound 3.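

In this assay, among the compounds shown here, the phenyl ring proves sensitive to substitution, since methyl in place of hydrogen, meta to a large group, gives a 2.1-fold higher number from compound 2 to compound 3 (0.32 log units; beyond the scatter) and is the first step on record to pass beyond the scatter. For the compounds shown here, the only earlier step, a 1.1-fold higher number from compound 1 to compound 2 (0.04 log units; within the scatter), concerned the side chain on the shared core and showed no such effect, so this modest rise, moving toward a weaker inhibitor, is the first sign that this position is less tolerant of change than that side chain. No evidence at hand accounts for the rise.

The compounds shown leave open whether a chlorine atom or a methoxy group on the same aromatic carbon would also raise the number, and whether an ethyl group would raise it further. They also leave open whether methyl would give a similar step on another carbon of this ring, or alongside the side chain of compound 1.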